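The source may hold more compounds than are shown below. What is called first, only, known or untested is meant among the compounds shown, and "the series" means these compounds.

Measured so far:
compound 1 `C#CCSc1nnc(CCC)n1N1C(=O)c2ccccc2C1=O` — in a functional assay on MKN-45 cells (Homo sapiens) for cytotoxicity, read by MTT assay, with a stated time of 48 h (a higher number here means a weaker inhibitor, a lower number a stronger inhibitor), a limit only, > 200000 nM
compound 2 `C=CCSc1nnc(-c2cc(OC)c(OC)c(OC)c2)n1N1C(=O)c2ccccc2C1=O` — in this assay a limit only, > 200000 nM

Compound 2 stands at the limit of this assay rather than at a number, the same place at which compound 1 sits (the limit of > 200000 nM in this assay, at which 2 of the 2 values shown sit). For the measured compounds named here, no step between the measured compounds can be stated; of the two values only this much is known, that neither is a number.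

Compound 3 `COc1cc(-c2nnc(SCC(=O)c3ccc(F)c(F)c3)n2N2C(=O)c3ccccc3C2=O)cc(OC)c1OC` differs from compound 2 by the change ((3,4-difluorophenyl)carbonyl in place of vinyl on a saturated chain carbon bound to a sulfur). With both known values sitting at the limit, no step beyond the scatter in this assay can be predicted in either direction. Compound 3 is expected most likely to return a limit again, with an estimate of 150000 nM in a range from 40000 nM to 500000 nM. The step of an at least 1.3-fold lower number from compound 2 to compound 3 (0.12 log units; that floor lies within the scatter) is expected to stay within the scatter.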

Compound 3, half-maximal inhibitory concentration: > 200000 nM
Compound 3 was reported as a limit; the forecaster's own chance of this, stated with the estimate: 65%; middle value at least 1.3-fold (0.12 log units) away from the limit.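

In this assay compound 2 and compound 3 each give only a limit, not a number, so no step between them can be read: the limit of > 200000 nM in this assay, at which 3 of the 3 values shown sit.

The compounds shown leave open which change on the shared core, if any, would give a number in this assay at all.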